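This account rests on a few compounds, and the source may have more. Where it says the series, first, only, none or still open, it means among the compounds named here.

Compound 1 `COc1cc(/C=C/C(=O)c2sc(Nc3cccc(Cl)c3)nc2C)cc(OC)c1OC` gives 11600 nM in a functional assay on BGC-823 cells (Homo sapiens) for cytotoxicity, read by MTT assay; on this read-out higher numbers stand for weaker inhibition and lower numbers for stronger inhibition. Compound 2 `COc1cc(/C=C/C(=O)c2sc(Nc3ccc(Cl)c(Cl)c3)nc2C)cc(OC)c1OC` reaches only the limit of this assay at > 25000 nM. Compound 3 `COc1cc(/C=C/C(=O)c2sc(Nc3ccc(F)c(Cl)c3)nc2C)cc(OC)c1OC` gives 9700 nM in this assay.

Among the two numbers read in this assay, compound 3 stands at the lower one, with compound 1 nearest: the step of a 1.2-fold lower number from compound 1 to compound 3 (0.08 log units; within the scatter) lies within the scatter, so the two cannot be ordered. Compound 2 sits at the limit of > 25000 nM in this assay, at which 1 of the 3 values shown sits.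

Compound 4 `COc1cc(/C=C/C(=O)c2sc(Nc3ccccc3)nc2C)cc(OC)c1OC` differs from compound 3 by phenyl in place of 3-chloro-4-fluorophenyl on a nitrogen on an aromatic ring, so both halogens on the anilino ring are removed at once. Among the compounds with values here, no measured pair shows this change directly. The steps that touch the same ring are a 1.2-fold lower number from compound 1 to compound 3 (0.08 log units; within the scatter), an at least 2.1-fold higher number from compound 1 to compound 2 (0.33 log units; beyond the scatter) and an at least 2.5-fold lower number from compound 2 to compound 3 (0.41 log units; beyond the scatter); adding fluoro changed little, while chloro at that place weakened inhibition. Removing the fluoro alone should therefore cost little, and the effect of removing the chloro as well is not covered by any measured step. The step of a 1.2-fold higher number from compound 3 to compound 4 (0.09 log units; within the scatter) is expected to remain small, in this assay. Compound 4 is estimated at 12000 nM, within 5000 nM to 28000 nM.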

Compound 4, half-maximal inhibitory concentration: > 25000 nM
Compound 4: no number, only a limit (the forecaster's own chance of this, stated with the estimate: 20%); at least 2.0-fold (0.31 log units) between middle value and limit.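

The reading for compound 4 in this assay is a limit and not a number, and compound 2 shares it: the limit of > 25000 nM in this assay, at which 2 of the 4 values shown sit.

Even so, the anilino ring proves sensitive to losing halogen, with phenyl in place of 3-chloro-4-fluorophenyl giving an at least 2.5-fold higher number from compound 3 to compound 4 (0.41 log units; beyond the scatter), and hydrogen in place of chloro giving an at least 2.1-fold higher number from compound 1 to compound 4 (0.33 log units; beyond the scatter). The earlier compounds had shown only that adding a halogen to compound 1 changed little or weakened inhibition, whereas removing the chloro weakens it as well, so among these four compounds inhibition is lost both by adding a chloro to compound 1 and by removing its chloro; the step between compound 2 and compound 4 cannot be read.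

The compounds shown leave open whether a 4-fluorophenyl ring, with the fluoro alone, would keep the inhibition seen with compound 1 and compound 3. They also leave open how a methoxy or a dimethylamino group on this ring would compare with the halogens.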